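The source may report more compounds than this note shows. Statements on the series, on what has been measured and on what is new or still open speak of the compounds shown alone.

Of the compounds shown here, two have been measured so far in a functional assay on HCT-116 cells (Homo sapiens) for cytotoxicity, read by sulforhodamine B assay, with a stated time of 48 h, tested at 1 uM; a lower number here means a stronger effect, a higher number a weaker effect of the compound at the concentration tested. Compound 1 `COc1ccc(-c2cc(/C=C/C(=O)c3ccc(N)cc3)[nH]n2)cc1` gives 67% in this assay. Compound 2 `COc1cc(-c2cc(/C=C/C(=O)c3ccc(N)cc3)[nH]n2)cc(OC)c1OC` gives 56% in this assay and stands as the lower of the two numbers, with compound 1 sitting beyond the usual scatter above it. The next compound, compound 3 `COc1ccc(-c2cc(/C=C/C(=O)c3ccc(N)cc3)[nH]n2)cc1OC`, has not yet been measured. Compared with compound 2, compound 3 carries hydrogen in place of methoxy on an aromatic carbon. Among the compounds with values here, no pair of measured compounds that differ in a single place is available to gauge what such a change does, and compound 1 and compound 2 differ from each other by more than this single change. The step that the estimate implies, a number 5 percentage points higher from compound 2 to compound 3 (within the scatter), is expected to be small, most likely a modest rise in the number, and possibly none beyond the scatter. For compound 3, the value expected in this assay is 61%, within the range 48% to 74%.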

Compound 3, a percentage reported as activity, at one concentration (the size of the read-out at that concentration, not a potency): 87%
Beside the measured number, compound 3's estimate is 26 percentage points below it, outside the stated range (above it).
By their numbers in this assay, from the lowest: compound 2; then compound 1; then compound 3.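

Hydrogen in place of methoxy on an aromatic carbon gives, in this assay, a number 31 percentage points higher from compound 2 to compound 3 (beyond the scatter) and, read from the other side, methoxy in place of hydrogen on an aromatic carbon of that ring gives a number 20 percentage points higher from compound 1 to compound 3 (beyond the scatter) and thus a weaker effect in both cases. Across these three compounds, a methoxy group at this place therefore has no single direction of its own: removing one from compound 2 and adding one to compound 1 both raise the number, so its effect depends on which other methoxy groups the ring carries. Nothing available explains this outcome.

On these data alone, whether a hydroxyl group, a chlorine atom or an ethoxy group at this place would keep the number of compound 2 or follow compound 3 remains open. So does whether the same dependence holds when the amine on the other ring is replaced by an amide.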